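The compounds below may be only part of what the source reports. "The series", "measured", "known", "first", "only" and "open" are said of these compounds alone.

Measured compounds:
compound 1, `COc1ccc(-c2nnc(SC/C(=N/O)c3ccccc3)n2-c2ccccc2)cc1`, gives 63%
compound 2, `COc1ccc(-c2nnc(SC/C(=N/O)c3ccccc3)n2-c2ccccc2)cc1OC`, gives 67%
compound 3, `O=C(CSc1nnc(-c2ccccc2)n1-c1ccccc1)c1ccccc1`, gives 64%

All three numbers come from a functional assay on the whole organism (strain albino) for inhibition, with Rattus norvegicus as the target, read by paw edema, with a stated time of 3 h, at a dose of 0.28 mmol/kg by the oral route; on this read-out higher numbers stand for more inhibition at the one dose given (going by the name of the read-out) and lower numbers for less inhibition. Compound 4, `COc1ccc(-c2nnc(SCC(=O)c3ccccc3)n2-c2ccccc2)cc1`, has not yet been measured in this assay. It differs from compound 3 by methoxy in place of hydrogen on an aromatic carbon. The same kind of change separates compound 1 from compound 2: methoxy in place of hydrogen on an aromatic carbon. The surroundings of the place are not the same word for word: in compound 2 the entering methoxy sits ortho to a methoxy group and meta to a large group, whereas in compound 4 it sits para to a large group. In this assay that change gave a number 4 percentage points higher from compound 1 to compound 2 (within the scatter), a step too small to stand out from the scatter of repeated measurements. How the core of compound 3 differs from the core of compound 1 is not broken down here. The values of compound 3 and compound 1 lie within the scatter of each other. On this basis compound 4 is expected to give about 66%, with a range from 56% to 76%. This estimate means a step of a number 2 percentage points higher from compound 3 to compound 4 (within the scatter), expected to be small because the same kind of change gave a number 4 percentage points higher from compound 1 to compound 2 (within the scatter).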

Compound 4, a percentage reported as inhibition, in the whole organism at one dose (the size of the read-out at that dose, not a potency): 58%
Estimate against measurement, compound 4: 8 percentage points above, and the stated range covers the measured number.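

In this assay, the change from phenyl to 4-methoxyphenyl gives a number 6 percentage points lower from compound 3 to compound 4 (within the scatter), and set beside the earlier case of the same change, the two steps cannot be told apart: the same change on two cores in this assay, a number 4 percentage points higher (within the scatter) from compound 1 to compound 2 and a number 6 percentage points lower (within the scatter) from compound 3 to compound 4, 10 percentage points apart, within the scatter of two such steps The step between the two cores themselves, a number 5 percentage points lower from compound 1 to compound 4 (within the scatter), is also small, so on these two cores neither the methoxy group nor the choice of core shows an effect that stands out from the scatter. Going by these compounds alone, this does not show that methoxy acts alike on both cores, only that two small steps, each taken from a single pair of compounds, cannot separate a real difference from ordinary variation.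

From the compounds shown here alone, whether an amine or a carboxylic acid in the place of the methoxy, or a longer chain on the sulfur, would give a step beyond the scatter stays open. Going by these compounds, with a single dose and a single time, how these compounds compare in potency stays open as well.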